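This account rests on a few compounds, and the source may have more. Where it says the series, first, only, none or still open, it means among the compounds named here.

Measured compounds in a functional assay on HCT-116 cells (Homo sapiens) for antiproliferative activity, read by MTT assay, with a stated time of 72 h; on this read-out higher numbers stand for weaker inhibition and lower numbers for stronger inhibition:
- compound 1, `COc1ccc(Oc2c(/C=N\OCc3c(Cl)c(-c4ccc(F)cc4)nn3C)c(C)nn2C)cc1`, 1180 nM
- compound 2, `Cc1nn(C)c(Oc2ccc(OC(F)(F)F)cc2)c1/C=N\OCc1c(Cl)c(-c2ccc(F)cc2)nn1C`, 2310 nM
- compound 3, `Cc1nn(C)c(Oc2ccc(Br)cc2)c1/C=N\OCc1c(Cl)c(-c2ccc(Cl)cc2)nn1C`, 5910 nM

Compound 1 shows the lowest of the three numbers in this assay. Its nearest neighbour is compound 2: a 2.0-fold higher number from compound 1 to compound 2 (0.29 log units; within the scatter), a step that does not leave the scatter. Among the compounds with values here, compound 3 stands furthest from it, with a gap beyond the scatter; compound 3 differs from compound 1 in two places, so no single step is drawn between them, and its value says only where a compound carrying both changes lands.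

Compound 4, `COc1ccc(Oc2c(/C=N\OCc3c(Cl)c(-c4ccc(Cl)cc4)nn3C)c(C)nn2C)cc1`, differs from compound 1 in one place: chloro in place of fluoro on an aromatic carbon. Within the data shown here, none of the measured steps covers this change. Among the measured compounds shown here, the only step that is measured, from compound 1 to compound 2, touches a different position and is itself within the scatter. For the measured compounds named here, with no step bearing on the fluoro-to-chloro exchange, no movement beyond the scatter is expected in this assay. Compound 4 is therefore estimated at 1500 nM, range 600 nM to 4000 nM, and the expected step is a 1.3-fold higher number from compound 1 to compound 4 (0.10 log units; within the scatter).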

Compound 4, half-maximal inhibitory concentration: 1260 nM
Compound 4: the middle estimate sits 1.2-fold (0.08 log units) above what was measured; the range from low to high includes it.
By their numbers in this assay, from the lowest: compounds 1, 4 and 2 (each within the scatter of the next); then compound 3.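

In this assay, 4-fluorophenyl to 4-chlorophenyl gives a 1.1-fold higher number from compound 1 to compound 4 (0.03 log units; within the scatter) and shows that, with the methoxy group held, this exchange of one halogen for another does not move the number beyond the scatter. Within the data shown here, with 4-chlorophenyl held, methoxy in place of bromo on an aromatic carbon gives a 4.7-fold lower number from compound 3 to compound 4 (0.67 log units; beyond the scatter) and is the first one-place step in these compounds to leave the scatter, so the difference between compound 3 and compound 1 can now be read largely at that other place. No measurement at hand accounts for either step.

From the compounds shown here alone, whether the bromo-to-methoxy step has the same size with 4-fluorophenyl in place of 4-chlorophenyl remains open. Also open, going by these compounds, is how the number responds at the position now carrying fluoro or chloro to a group other than a halogen, such as an amine or a carboxylic acid.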